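Benzoyl to Ethoxycarbonyl on a Thiophene Amine Core

The source may hold more compounds than are shown below. What is called first, only, known or untested is meant among the compounds shown, and "the series" means these compounds.

Measured compounds:
compound 1, `Nc1scc(-c2cccc(C(F)(F)F)c2)c1C(=O)c1ccccc1` — 61.1%
compound 2, `CC(=O)c1cccc(-c2sc(N)c(C(=O)c3ccccc3)c2-c2cccc(C(F)(F)F)c2)c1` — 33.1%

In an assay on CHO-K1 cells for displacement of a labelled ligand from adenosine receptor A1 (Homo sapiens), tested at 10 uM (on this read-out higher numbers stand for more inhibition at the one concentration tested (going by the name of the read-out) and lower numbers for less inhibition), compound 1 gives 61.1%. Compound 2 carries a 3-acetylphenyl in place of hydrogen on an aromatic carbon, and in this assay compound 2 gives 33.1%; the step is a number 28 percentage points lower from compound 1 to compound 2 (beyond the scatter). Within the data shown here, compound 2 therefore stands lowest of the two numbers, with compound 1 as its only neighbour, beyond the scatter.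

Compound 3, `CCOC(=O)c1c(N)sc(-c2cccc(C(C)=O)c2)c1-c1cccc(C(F)(F)F)c1`, is the next compound. It differs from compound 2 in one place: ethoxy in place of phenyl on a carbonyl carbon. Cut one bond further out, the difference reads benzoyl to ethoxycarbonyl. Among the measured compounds shown here, no measured step touches the carbonyl carbon or the phenyl on it; the single measured step concerns a different position. Nothing in the data therefore predicts a direction for this change, and no step beyond the scatter is expected in this assay. The estimate for compound 3 is 30%, within 5% to 55%, an expected step of a number 3.1 percentage points lower from compound 2 to compound 3 (within the scatter).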

Compound 3, a percentage reported as inhibition, at one concentration (the size of the read-out at that concentration, not a potency): 68.9%
Beside the measured number, compound 3's estimate is 38.9 percentage points below it; measured number above the stated range.
By their numbers in this assay, from the lowest: compound 2; then compounds 1 and 3 (each within the scatter of the next).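

In this assay, among these compounds, the group on the carbonyl carbon turns out to matter: benzoyl to ethoxycarbonyl gives a number 35.8 percentage points higher from compound 2 to compound 3 (beyond the scatter) as a large step, the first measured change at this position. Its direction is opposite to that of the earlier change at a different position, where 3-acetylphenyl in place of hydrogen on an aromatic carbon gave a number 28 percentage points lower from compound 1 to compound 2 (beyond the scatter) in the same assay, so the number here responds to changes at both places. No measurement available here bears on why the swap of phenyl for ethoxy has this effect.

Among the compounds shown here, whether the step holds when the 3-acetylphenyl is absent remains open, as the change is seen only with that group present. Also open, as far as these compounds go, is how the number would respond to other groups on the carbonyl carbon, such as methoxy, a longer alkoxy chain, an amine or a hydroxyl.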